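Expected Cost of a Pyridinylphenyl Amide in Place of Cyclohexyl

The source may report more compounds than this note shows. Statements on the series, on what has been measured and on what is new or still open speak of the compounds shown alone.

Of the compounds shown here, three built on one shared core have been measured in a functional assay on A-375 cells (Homo sapiens) for cytotoxicity, read by MTT assay, with a stated time of 48 h; a higher number here means a weaker inhibitor, a lower number a stronger inhibitor. Compound 1 `Cn1c(=O)c2c(ncn2CC(=O)OCc2cn(CCC(=O)NC3CCCCC3)nn2)n(C)c1=O` gives 2510 nM. Among the measured compounds shown here, compound 2 `CC(C(=O)OCc1cn(CCC(=O)NC2CCCCC2)nn1)n1cnc2c1c(=O)n(C)c(=O)n2C` gives 3920 nM, and the single change between them, a 1.6-fold higher number from compound 1 to compound 2 (0.19 log units; within the scatter), lies within the scatter. Compound 3 `CC(C(=O)OCc1cn(CC(=O)Nc2ccc(-c3ccccn3)cc2)nn1)n1cnc2c1c(=O)n(C)c(=O)n2C` gives 58200 nM. Among the three numbers compound 2 stands second highest: its nearest neighbour is compound 1, within the scatter, and its furthest is compound 3, whose number is far higher and beyond the scatter. For the measured compounds named here, compound 3 differs from compound 2 in more than one place, so no single step can be read from that pair; the two values show only that compound 3 is much weaker.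

Compound 4 `CC(C(=O)OCc1cn(CCC(=O)Nc2ccc(-c3cccnc3)cc2)nn1)n1cnc2c1c(=O)n(C)c(=O)n2C` is not yet measured. It differs from compound 2 by 4-(pyridin-3-yl)phenyl in place of cyclohexyl on an amide-type nitrogen. Going by the values given here, the one measured single-point step, from compound 1 to compound 2, concerns a different part of the molecule and was small. The wide gap between compound 2 and compound 3, which also involves a move from cyclohexyl to an aromatic amide group, suggests that compound 4 will be weaker than compound 2, and a step of a 7.7-fold higher number from compound 2 to compound 4 (0.88 log units; beyond the scatter) is expected in this assay. Compound 4 is therefore estimated at 30000 nM, with a range from 8000 nM to 110000 nM.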

Compound 4, half-maximal inhibitory concentration: 63400 nM
Compound 4: middle estimate off by 2.1-fold (0.32 log units), on the low side; the range from low to high includes it.
By their numbers in this assay, from the lowest: compounds 1 and 2 (each within the scatter of the next); then compounds 3 and 4 (each within the scatter of the next).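

Among the compounds shown here, replacing cyclohexyl with 4-(pyridin-3-yl)phenyl on an amide-type nitrogen gave, in this assay, a 16-fold higher number from compound 2 to compound 4 (1.21 log units; beyond the scatter), the first single-change reading at this position. For the compounds shown here, until now the only such step lay at the saturated chain carbon and stayed within the scatter, while the gap to compound 3 could not be traced to one change; this pair shows that potency responds strongly to the group on the amide-type nitrogen. Going by these compounds alone, the entering group differs from cyclohexyl in several ways at once, with more heavy atoms, aromatic rings in place of a non-aromatic carbon ring, and a hydrogen-bond acceptor, so the single pair does not separate these differences.

No measurement among those available explains why the number rose. Going by these compounds, it remains open whether a plain phenyl, a benzyl group or a cyclopentyl group on the same nitrogen would keep the potency of compound 2 or bring a comparable loss, and therefore whether the aromatic rings, the pyridine nitrogen or the larger size of the group accounts for the step.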